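This account rests on a few compounds, and the source may have more. Where it says the series, first, only, none or still open, it means among the compounds named here.

Three compounds with one shared core differ only in the aromatic ring that sits on a saturated chain carbon bound to an amine nitrogen in a ring. Compound 3 `Cc1ccc(CN2Cc3c(NC(=O)c4ccccc4)n[nH]c3C2(C)C)cc1F` carries a 3-fluoro-4-methylphenyl there, and in an assay on Sf21 cells for inhibition of high affinity nerve growth factor receptor (Homo sapiens), read by HTRF, with a stated time of 30 min, in the presence of a further agent that is not named here (a higher number here means a weaker inhibitor, a lower number a stronger inhibitor), compound 3 gives 940 nM. Compound 1 `CC1(C)c2[nH]nc(NC(=O)c3ccccc3)c2CN1Cc1cccc(Br)c1` gives 940 nM in this assay, and compound 2 `CC1(C)c2[nH]nc(NC(=O)c3ccccc3)c2CN1Cc1c(F)cccc1F` gives 520 nM. The three numbers lie within the usual scatter of one another: there is no change at the digits printed from compound 1 to compound 3 (within the scatter), a 1.8-fold higher number from compound 2 to compound 3 (0.26 log units; within the scatter), and a 1.8-fold lower number from compound 1 to compound 2 (0.26 log units; within the scatter). Compound 3 therefore stands at one of the two matching numbers among the three, with nothing separating it from the others beyond the scatter.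

Compound 4 `CC1(C)c2[nH]nc(NC(=O)c3ccccc3)c2CN1Cc1cc(F)c(F)c(F)c1` is not yet measured. It differs from compound 3 by 3,4,5-trifluorophenyl in place of 3-fluoro-4-methylphenyl on a saturated chain carbon bound to an amine nitrogen in a ring. All three known steps concern exactly this kind of exchange, one aromatic ring for another at the same place, and none of them moved the number beyond the scatter. On that basis the step is expected to be a 1.0-fold lower number from compound 3 to compound 4 (0.02 log units; within the scatter), that is, no change beyond the scatter. Compound 4 is accordingly estimated at 900 nM in this assay, with a range from 350 nM to 2300 nM.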

Compound 4, half-maximal inhibitory concentration: 6960 nM
Compound 4: the middle estimate sits 7.7-fold (0.89 log units) below what was measured; the whole stated range lies below it.
By their numbers in this assay, from the lowest: compounds 2, 1 and 3 (each within the scatter of the next); then compound 4.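

Among these compounds, the ring at this place is not as freely exchangeable as the earlier compounds suggested: in this assay the change to 3,4,5-trifluorophenyl gives a step beyond the scatter from each of the other three rings (a 7.4-fold higher number from compound 3 to compound 4 (0.87 log units; beyond the scatter); a 7.4-fold higher number from compound 1 to compound 4 (0.87 log units; beyond the scatter); a 13-fold higher number from compound 2 to compound 4 (1.13 log units; beyond the scatter)). The count of fluorine atoms alone does not sort the set, as compounds 1, 2 and 3 carry different numbers of fluorine atoms and remain within the scatter of one another, while compound 2, which has two fluorine atoms on its ring, shows the largest of the three steps to compound 4. No measurement is available that accounts for the loss seen with compound 4.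

The compounds shown leave open whether the step depends on having three fluorine atoms or on their arrangement, a question that 3,4-difluorophenyl and 3,5-difluorophenyl at this place could help separate. They also leave open how an unsubstituted phenyl, or a ring bearing a methoxy group or an amine, would behave here.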